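This account rests on a few compounds, and the source may have more. Where it says the series, first, only, none or still open, it means among the compounds named here.

Values so far in a physicochemical assay for solubility, read by spectrophotometry, in phosphate buffer, with a stated time of 18 h, at pH 7.4; a higher number here means a more soluble compound, a lower number a less soluble compound
- compound 1 `CCc1ccc(-c2nc3c(c(C)nn3-c3ccccc3)c(-c3ccccc3I)c2C#N)cc1` gives 8500 nM
- compound 2 `CCc1ccc(-c2nc3c(c(C)nn3-c3ccccc3)c(-c3ccccc3OC)c2C#N)cc1` gives 7800 nM
- compound 3 `Cc1cccc(-c2nc3c(c(C)nn3-c3ccccc3)c(-c3ccccc3O)c2C#N)c1` gives 42000 nM

Compound 3 (42000 nM) holds the highest of these three numbers, clear of both others by more than the scatter. Compound 4 `Cc1nn(-c2ccccc2)c2nc(-c3ccc(Cl)cc3)c(C#N)c(-c3ccccc3O)c12` is not yet measured and departs from compound 3 at one place: 4-chlorophenyl in place of 3-methylphenyl on an aromatic carbon (4-chlorophenyl in place of 3-methylphenyl on an aromatic carbon, ortho to a cyano group and next to the ring nitrogen). The 2-hydroxyphenyl group stays. Among the measured compounds shown here, the only measured single-place step (a 1.1-fold lower number from compound 1 to compound 2 (0.04 log units; within the scatter)) is methoxy in place of iodo, lies within the scatter and does not touch this position, so no measured step tests this exchange. Compound 1 and compound 2 differ from compound 3 in more than one place, so their lower values cannot be assigned to any one change. In this assay a step within the scatter is therefore expected, leaning slightly lower since compound 3 sits at the top of the range. The estimated change is a 1.4-fold lower number from compound 3 to compound 4 (0.15 log units; within the scatter) in this expectation. The estimate for compound 4 is 30000 nM, with an expected range from 12000 nM to 65000 nM for the measurement.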

Compound 4, solubility: 3800 nM
Beside the measured number, compound 4's estimate is 7.9-fold (0.90 log units) above it; the whole stated range lies above it.
By their numbers in this assay, from the lowest: compound 4; then compounds 2 and 1 (each within the scatter of the next); then compound 3.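

In this assay the exchange of 3-methylphenyl for 4-chlorophenyl, on the aromatic carbon ortho to a cyano group and next to the ring nitrogen, gives an 11-fold lower number from compound 3 to compound 4 (1.04 log units; beyond the scatter) with the 2-hydroxyphenyl group unchanged. The earlier compounds shown here held no single-place step at this position, so this is its first reading, and it shows that two groups with the same number of heavy atoms can stand far apart here. Nothing measured here says why the step is so large.

The two groups differ both in their substituent and in where it sits on the phenyl ring, so the compounds shown cannot separate these two changes. From the compounds shown here alone, whether 4-methylphenyl, 3-chlorophenyl, or a phenyl ring carrying an amine or a carboxylic acid would stay nearer compound 3 also remains open.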